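A few compounds are considered here, and "the series" means these few. Any claim that something is new, unique, unknown or untested is made for them only; others in the source may bear on it.

Measured compounds:
compound 1 `COc1ccc(-c2cc(/C=C/C(=O)c3ccc(N)cc3)[nH]n2)cc1`: 1470 nM in a functional assay on T47D cells (Homo sapiens) for inhibition, read by sulforhodamine B assay, with a stated time of 48 h; on this read-out higher numbers stand for weaker inhibition of growth and lower numbers for stronger inhibition of growth
compound 2 `COc1cc(-c2cc(/C=C/C(=O)c3ccc(N)cc3)[nH]n2)cc(OC)c1OC`: 1420 nM
compound 3 `COc1ccc(C(=O)/C=C/c2cc(-c3cc(OC)c(OC)c(OC)c3)n[nH]2)cc1OC`: 1630 nM

Compound 2 gives the lowest of the three numbers in this assay, but compound 1 and compound 3 both lie within the scatter of it, so no order among them is claimed. Compound 4 `COc1ccc(-c2cc(/C=C/C(=O)c3ccc(N)cc3)[nH]n2)cc1OC` differs from compound 2 by hydrogen in place of methoxy on an aromatic carbon. Going by the values given here, the only step between measured compounds, a 1.1-fold higher number from compound 2 to compound 3 (0.06 log units; within the scatter), alters the aryl on the carbonyl and leaves the ring changed here untouched, so it bears only indirectly. Compound 1, which carries a single methoxy on that ring, gives 1470 nM; compound 2 gives 1420 nM; the two lie within the scatter. No step beyond the scatter is therefore expected in this assay. Compound 4 is estimated at 1450 nM, range 700 nM to 3000 nM, an expected 1.0-fold higher number from compound 2 to compound 4 (0.01 log units; within the scatter).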

Compound 4, concentration for 50% growth inhibition: 4250 nM
Compound 4: middle estimate off by 2.9-fold (0.47 log units), on the low side, outside the stated range (above it).
By their numbers in this assay, from the lowest: compounds 2, 1 and 3 (each within the scatter of the next); then compound 4.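

In this assay, the methoxy pattern on this six-membered aromatic ring matters: growth inhibition weakens when methoxy is replaced by hydrogen (a 3.0-fold higher number from compound 2 to compound 4 (0.48 log units; beyond the scatter)), and also when methoxy replaces hydrogen (a 2.9-fold higher number from compound 1 to compound 4 (0.46 log units; beyond the scatter)). The read-out therefore does not follow methoxy count across compounds 1, 4 and 2, since compound 4 stands apart from two compounds that lie within the scatter of each other. No available data address the origin of this pattern.

As far as these compounds go, whether a hydroxy group, fluorine or an amine at this carbon would behave like hydrogen or like methoxy remains open. Also open, from the compounds shown here alone, is whether the pattern persists with 3,4-dimethoxyphenyl on the carbonyl carbon.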